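The source may report more compounds than this note shows. Statements on the series, on what has been measured and on what is new or still open speak of the compounds shown alone.

Measured compounds:
- compound 1, `C[C@H](O)[C@@H](CCc1cccc(-c2nccs2)c1)n1cnc2c(N)ncnc21`, 2.6 nM
- compound 2, `CNC(=O)c1cccc(CC[C@H]([C@H](C)O)n2cnc3c(N)ncnc32)c1`, 2.7 nM

Both compounds were tested in an assay on isolated protein for inhibition of adenosine deaminase (Bos taurus), with a stated time of 5 min; a higher number here means a weaker inhibitor, a lower number a stronger inhibitor. Among the measured compounds shown here, compound 1 gives 2.6 nM and compound 2 gives 2.7 nM; the only step between them, a 1.0-fold higher number from compound 1 to compound 2 (0.02 log units; within the scatter), lies within the scatter, so compound 2 cannot be separated from compound 1 on these numbers.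

Compound 3, `C[C@H](O)[C@@H](CCc1cccc(C(=O)N2CCCC2)c1)n1cnc2c(N)ncnc21`, has not yet been measured in this assay. It differs from compound 2 in one place: pyrrolidin-1-yl in place of methylamino on a carbonyl carbon. For the measured compounds named here, the one measured step, a 1.0-fold higher number from compound 1 to compound 2 (0.02 log units; within the scatter), concerns the substituent on the aromatic carbon rather than the amide nitrogen, so it bears only loosely on this change; it shows that exchanging the group at that position left the number unchanged beyond the scatter. Going by the values given here, no measured step speaks to the amide nitrogen itself.

Compound 3 is therefore expected to stay close to compound 2, with an expected step of a 1.5-fold higher number from compound 2 to compound 3 (0.17 log units; within the scatter) in this assay, not beyond the scatter. The estimate for compound 3 is 4 nM, in a range from 1.5 nM to 12 nM.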

Compound 3, inhibition constant: 2.2 nM
For compound 3 the middle estimate is 1.8-fold (0.26 log units) above the measured one, within the range that was stated.
By their numbers in this assay, from the lowest: compounds 3, 1 and 2 (each within the scatter of the next).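

In this assay, the amide nitrogen now has a measured change of its own: pyrrolidin-1-yl in place of methylamino on the carbonyl carbon gives a 1.2-fold lower number from compound 2 to compound 3 (0.09 log units; within the scatter) and so stays within the scatter, even though the hydrogen-bond donor of methylamino leaves and a five-membered non-aromatic ring enters. The comparison on the aromatic carbon also gains a third group, since (pyrrolidin-1-yl)carbonyl in place of 1,3-thiazol-2-yl gives a 1.2-fold lower number from compound 1 to compound 3 (0.07 log units; within the scatter) and is likewise within the scatter, so the three groups at this place cannot be separated on these numbers. No measurement is available that would explain why these exchanges leave the number where it is.

The compounds shown leave open whether any group on this aromatic carbon would move the number beyond the scatter, for example a carboxylic acid or a primary amine, or whether a larger ring on the carbonyl carbon, such as piperidin-1-yl or morpholin-4-yl, would do so. They also leave open whether the tolerance seen here would hold with a change to the shared core or in any other kind of test.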